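This account rests on a few compounds, and the source may have more. Where it says the series, first, only, none or still open, it means among the compounds named here.

Compound 1, `O=C1c2ccccc2NS(=O)(=O)N1COCCO`: in a functional assay on HEL cells (Homo sapiens) (a lower number here means that less compound is tolerated, a higher number that more compound is tolerated), compound 1 gives 160 ug/mL.
Compound 2, `CC(=O)OCCOCN1C(=O)c2ccccc2NS1(=O)=O`: for compound 2 the result is a limit of the assay and not a number, > 200 ug/mL.
Compound 3, `O=C1c2ccccc2N(COCCO)S(=O)(=O)N1Cc1ccccc1`: in this assay compound 3 gives 125 ug/mL.

Compound 2 differs from compound 1 by acetyl in place of hydrogen on an oxygen on a saturated carbon. Since the result for compound 2 is a limit, the step of an at least 1.2-fold higher number from compound 1 to compound 2 (0.09 log units; that floor lies within the scatter) has only a floor, set by the limit of > 200 ug/mL in this assay, at which 1 of the 3 values shown sits. Compound 3 shares a core with compound 1, but the difference between the two cores is not broken down here. The values of compound 1 and compound 3 lie within the scatter of each other, so nothing can be said about any order between them.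

Compound 4, `CC(=O)OCCOCN1c2ccccc2C(=O)N(Cc2ccccc2)S1(=O)=O`, is not yet measured. It differs from compound 3 by acetyl in place of hydrogen on an oxygen on a saturated carbon. The place of this change reads word for word the same as in the pair of compound 1 and compound 2, so it is the same change, made a second time. For the measured compounds named here, its one measured instance raised the number by a floor that itself lies within the scatter, with the true size hidden behind the limit. For compound 4 a step of a 1.4-fold higher number from compound 3 to compound 4 (0.13 log units; within the scatter) is expected, resting on compound 3 with its 125 ug/mL and on the measured step of an at least 1.2-fold higher number from compound 1 to compound 2 (0.09 log units; that floor lies within the scatter). Compound 4 is estimated at 170 ug/mL, with an expected range from 110 ug/mL to 280 ug/mL. The estimate leaves open that compound 4, like compound 2, may return only a limit.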

Compound 4, half-maximal cytotoxic concentration: 100 ug/mL
Compound 4: middle estimate off by 1.7-fold (0.23 log units), on the high side, outside the stated range (below it).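

Putting acetyl in place of hydrogen on the oxygen of the side chain, that is, going from 2-hydroxyethyl to 2-acetoxyethyl, gives a 1.3-fold lower number from compound 3 to compound 4 (0.10 log units; within the scatter) in this assay. Set beside the same change on the core of compound 1, the two cases read: the same change on two cores in this assay, an at least 1.2-fold higher number (0.09 log units; that floor lies within the scatter) from compound 1 to compound 2 and a 1.3-fold lower number (0.10 log units; within the scatter) from compound 3 to compound 4; the limit leaves it open whether they differ. For the compounds shown here, this shows only that on the core of compound 3 the change leaves the number within the usual scatter; it does not show that the change acts alike on both cores, nor that it acts differently, because compound 2 returned a limit and not a number: the limit of > 200 ug/mL in this assay, at which 1 of the 4 values shown sits.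

The compounds shown carry only hydrogen or acetyl on this oxygen and sit on only two cores, so it remains open whether a longer ester such as butyryl, or an amine or a carboxylic acid at the end of the chain, would move the number beyond the scatter. Also open, going by these compounds, is how the change would read on a further core, where both members of the pair give true numbers rather than a limit, since only such a pair could show whether the step carries over.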